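Methyl Walk Around a Pyrazole on a Shared Core

The compounds below may be only part of what the source reports. "The series", "measured", "known", "first", "only" and "open" are said of these compounds alone.

Three compounds have been measured in an assay on SW48 cells for inhibition of Tryptophan 2,3-dioxygenase (Homo sapiens), read by fluorescence, with a stated time of 30 min; a higher number here means that more compound is needed for the effect, a lower number that less compound is needed:

Compound 1 `Nc1oncc1-c1cccnc1`: 1400 nM
Compound 2 `Nc1oncc1-n1cccn1`: 230 nM
Compound 3 `Cc1ccn(-c2cnoc2N)n1`: 810 nM

Compound 2 gives the lowest number of the three in this assay. Its nearest neighbour is compound 3, and the step of a 3.5-fold higher number from compound 2 to compound 3 (0.55 log units; beyond the scatter) lies beyond the scatter; compound 1 stands further away still, its value in this assay being the highest of the set.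

Compound 4 `Cc1cnn(-c2cnoc2N)c1` is not yet measured. It differs from compound 2 in one place: methyl in place of hydrogen on an aromatic carbon. Within the data shown here, the only measured step that bears on this change is the one from compound 2 to compound 3, where a methyl entering at another aromatic carbon of the same ring gave a 3.5-fold higher number from compound 2 to compound 3 (0.55 log units; beyond the scatter), a modest rise. A methyl at the present carbon is not covered by any measured pair, so the expectation rests on that single step alone.

On that basis compound 4 is expected to give a somewhat higher number than compound 2, with an estimated step of a 2.0-fold higher number from compound 2 to compound 4 (0.29 log units; within the scatter). The estimate for compound 4 in this assay is 450 nM, with a range from 200 nM to 1100 nM.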

Compound 4, half-maximal effective concentration: 340 nM
Beside the measured number, compound 4's estimate is 1.3-fold (0.12 log units) above it; the range from low to high includes it.
By their numbers in this assay, from the lowest: compounds 2 and 4 (each within the scatter of the next); then compounds 3 and 1 (each within the scatter of the next).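

In this assay a methyl on this aromatic carbon, two ring bonds from the ring nitrogen and two ring bonds from the ring atom that bears a group of 6 heavy atoms, gives a step that stays inside the scatter (a 1.5-fold higher number from compound 2 to compound 4 (0.17 log units; within the scatter)), so compound 4 cannot be told apart from compound 2 by this measure. Among these compounds, the only earlier methyl step lay at another carbon of the same ring and stood beyond the scatter (a 3.5-fold higher number from compound 2 to compound 3 (0.55 log units; beyond the scatter)), so the same exchange of hydrogen for methyl does not read alike at these two carbons, a statement that holds for compound 3 and compound 4 alone. Nothing at hand accounts for why the two steps differ.

On these data alone, whether this carbon would also accommodate something other than methyl stays open, since an ethyl, a methoxy, an amine or a carboxylic acid at the same place could behave quite differently. As far as these compounds go, it is equally open whether the reading for methyl carries over to the remaining carbon of the ring, or to the same methyl on a core other than the shared core.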